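Restoring a tetrazole on the chain of compound 2

The source may hold more compounds than are shown below. What is called first, only, known or untested is meant among the compounds shown, and "the series" means these compounds.

Among the compounds with values here, compound 2 `CCc1cc(C(C)=O)c(O)cc1OCCCCCCSC` stands lowest of the two compounds measured so far in an assay on isolated protein for binding affinity to leukotriene B4 receptor 1 (Homo sapiens), tested at 1 uM; a lower number here means less inhibition, a higher number more inhibition at the concentration tested (going by the name of the read-out): compound 2 gives 14%, while compound 1 `CCc1cc(C(C)=O)c(O)cc1OCCCCCCC(C)(C)c1nnn[nH]1` gives 67%. Within the data shown here, only one measured step exists, and it bears directly on the next compound: a number 53 percentage points lower from compound 1 to compound 2 (beyond the scatter). Compound 3 `CCc1cc(C(C)=O)c(O)cc1OCCCCCCc1nnn[nH]1` differs from compound 2 by 1H-tetrazol-5-yl in place of methylsulfanyl on a saturated chain carbon, six bonds along the chain from an oxygen on an aromatic ring. This is nearly the reverse of the measured step, except that the tetrazole ring of compound 3 sits on the chain without the methyl branching that the group in compound 1 carries. A large rise in this assay is expected because the step of a number 53 percentage points lower from compound 1 to compound 2 (beyond the scatter) was large and went the other way when the tetrazole-bearing group was removed. The missing methyl branching leaves some doubt about whether the whole loss is recovered, so the expected rise is taken as somewhat short of a full return to compound 1. The step expected here is a number 36 percentage points higher from compound 2 to compound 3 (beyond the scatter). Compound 3 is therefore estimated at 50%, with a range from 25% to 75%.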

Compound 3, a percentage reported as inhibition, at one concentration (the size of the read-out at that concentration, not a potency): 60%
Beside the measured number, compound 3's estimate is 10 percentage points below it, and the stated range covers the measured number.
By their numbers in this assay, from the lowest: compound 2; then compounds 3 and 1 (each within the scatter of the next).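

With 1H-tetrazol-5-yl in place of methylsulfanyl on a saturated chain carbon, six bonds along the chain from an oxygen on an aromatic ring, this assay shows a number 46 percentage points higher from compound 2 to compound 3 (beyond the scatter), so the ring alone, without any methyl branching, is enough for a large change at this position. Within the data shown here, removing the branching leaves a number 7 percentage points lower from compound 1 to compound 3 (within the scatter), and the two compounds cannot be told apart in this read-out, which the single earlier step could not show. Across these three compounds, then, the large difference goes with the presence of the tetrazole ring and not with the methyl branching, although three compounds are a narrow basis and the read-out, taken at one concentration, is not a potency. The data shown offer no explanation for the effect of the ring.

On these data alone, whether the ring itself is required remains open, since a carboxylic acid at the same chain end could match it or fall well short. The compounds shown also leave unsettled how far the result depends on the chain, as all three carry the same length and a longer or shorter chain could place the tetrazole differently.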